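Swapping Hydroxy for Methoxy in Compound 2

A few compounds are considered here, and "the series" means these few. Any claim that something is new, unique, unknown or untested is made for them only; others in the source may bear on it.

In an ADME assay on HEK293 cells (Homo sapiens) for cytotoxicity, read by reporter gene assay and resazurin assay, with a stated time of 48 h (a lower number here means that less compound is tolerated, a higher number that more compound is tolerated), compound 2 (`O=C(Nc1ccccc1)c1cc(Br)ccc1O`) gives 35000 nM as its reading. Compound 3 (`O=C(Nc1cccc(Cl)c1)c1cccc(Br)c1`) gives 51000 nM and lies within the usual scatter of compound 2. Compound 1 (`COc1c(Br)cc(Br)cc1C(=O)Nc1ccccc1`), which carries methoxy, gives > 100000 nM as a limit of the assay, not a number. Compound 4 (`COc1ccc(Br)cc1C(=O)Nc1ccccc1`) differs from compound 2 by hydroxy to methoxy, with methyl in place of hydrogen on an oxygen on an aromatic ring. For the measured compounds named here, no measured pair shows this change alone. Going by the values given here, compound 1 at > 100000 nM is the only methoxy reading, so a small step toward a higher number is expected, close to the scatter. The expected change is a 1.7-fold higher number from compound 2 to compound 4 (0.23 log units; within the scatter) in this assay and remains a rough estimate. For compound 4 the estimated value is 60000 nM with an expected range of 30000 nM to 100000 nM here.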

Compound 4, half-maximal cytotoxic concentration: > 100000 nM
Compound 4 was reported as a limit; the forecaster's own chance of this, stated with the estimate: 30%; middle value at least 1.6-fold (0.22 log units) away from the limit.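

In this assay, for the compounds shown here, methyl in place of hydrogen on an oxygen on an aromatic ring now has a step of its own, seen alone for the first time: an at least 2.8-fold higher number from compound 2 to compound 4 (0.45 log units; beyond the scatter). So on this oxygen, hydroxy to methoxy goes with more compound being tolerated, beyond the scatter. The full size of the step and the step from compound 1 cannot be read because the readings stop at a limit: the limit of > 100000 nM in this assay, at which 2 of the 4 values shown sit. Still open, on these data alone, is whether an ethyl group on this oxygen, or an amine in place of hydroxy, would read like methoxy or like hydroxy.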